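Solubility notes: bicyclic amine swap on the side chain

The source may report more compounds than this note shows. Statements on the series, on what has been measured and on what is new or still open speak of the compounds shown alone.

The shared core carries a side chain on a saturated chain carbon bound to a saturated ring carbon. Compound 1 `COc1ccc2[nH]c(C(=O)N3CC(=O)N(Cc4ccccc4)[C@@H](CCc4ccccc4)C3)cc2c1` gives 4400 nM in a physicochemical assay for solubility, read by spectrophotometry, in phosphate buffer, with a stated time of 2 h, at pH 7.4; a lower number here means a less soluble compound, a higher number a more soluble compound. Compound 2 `COc1ccc2[nH]c(C(=O)N3CC(=O)N(Cc4ccccc4)[C@@H](CN4CCC(OC)CC4)C3)cc2c1` reaches only a limit of this assay, > 25000 nM, which is one of the values at the limit of > 25000 nM in this assay, at which 1 of the 3 values shown sits. Compound 3 `COc1ccc2[nH]c(C(=O)N3CC(=O)N(Cc4ccccc4)[C@@H](CN4CC5CCCCC5C4)C3)cc2c1` gives 23800 nM, the highest of the two numbers shown; the nearest number is that of compound 1, with a 5.4-fold higher number from compound 1 to compound 3 (0.73 log units; beyond the scatter). Compound 2 and compound 3 lie within the scatter of one another: an at least 1.0-fold lower number from compound 2 to compound 3 (0.02 log units; that floor lies within the scatter).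

Compound 4 `COc1ccc2[nH]c(C(=O)N3CC(=O)N(Cc4ccccc4)[C@@H](CN4CCc5ccccc5C4)C3)cc2c1` is to be measured; its change from compound 3 is a group of 10 heavy atoms (9 carbon, 1 nitrogen; one six-membered non-aromatic ring with 1 hetero atom, one six-membered aromatic ring of carbon only) in place of a group of 9 heavy atoms (8 carbon, 1 nitrogen; one five-membered non-aromatic ring with 1 hetero atom, one six-membered non-aromatic ring of carbon only), on a saturated chain carbon bound to a saturated ring carbon. The entering group keeps one hydrogen-bond acceptor, as the leaving group does, but brings back an aromatic ring as in compound 1. Within the data shown here, the steps that bear on it are an at least 5.6-fold higher number from compound 1 to compound 2 (0.75 log units; beyond the scatter) and a 5.4-fold higher number from compound 1 to compound 3 (0.73 log units; beyond the scatter), both of which move with the nitrogen-bearing groups. For compound 4 a step of a 1.7-fold lower number from compound 3 to compound 4 (0.23 log units; within the scatter) is expected in this assay, a modest fall that stays near the scatter. Compound 4 is therefore estimated at 14000 nM, with a range of 6000 nM to 28000 nM.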

Compound 4, solubility: 9000 nM
Compound 4: middle estimate off by 1.6-fold (0.19 log units), on the high side; measured number inside the range.
By their numbers in this assay, from the lowest: compound 1; then compound 4; then compound 3. At a limit, above all of these: compound 2.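

In this assay, the nitrogen-bearing groups on a saturated chain carbon bound to a saturated ring carbon now separate, where compound 2 and compound 3 could not be told apart: a 2.6-fold lower number from compound 3 to compound 4 (0.42 log units; beyond the scatter). Against benzyl, 1,2,3,4-tetrahydroisoquinolin-2-yl still gives a rise beyond the scatter: a 2.0-fold higher number from compound 1 to compound 4 (0.31 log units; beyond the scatter). Compound 2 gives only a limit, so an at least 2.7-fold lower number from compound 2 to compound 4 (0.44 log units; beyond the scatter) is a floor on the step rather than its size, with the limit noted here: the limit of > 25000 nM in this assay, at which 1 of the 4 values shown sits.

The change from compound 3 to compound 4 alters both the ring sizes and the presence of an aromatic ring, and the compounds shown do not separate these two. A morpholin-4-yl group or an open-chain amine such as dimethylamino in this place would show whether the order holds beyond these ring amines.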